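Carboxy to hydroxymethyl on two amine-linked side chains

The source may report more compounds than this note shows. Statements on the series, on what has been measured and on what is new or still open speak of the compounds shown alone.

Measured so far:
- compound 1 `O=C(O)CCCN1CCC(c2nc(-c3ccc4ccccc4c3)no2)CC1`: 25700 nM
- compound 2 `OCCCCN1CCC(c2nc(-c3ccc4ccccc4c3)no2)CC1`: 1170 nM
- compound 3 `O=C(O)CCN1CCC[C@H]1c1nc(-c2ccc3ccccc3c2)no1`: 28400 nM

All three were read in an assay on HepG2 cells for antagonist activity at Bile acid receptor (Homo sapiens), read by a luciferase reporter; a higher number here means a weaker inhibitor, a lower number a stronger inhibitor. Compound 1 gives 25700 nM and compound 3 gives 28400 nM; the two values lie within the scatter of each other, so no order between them is claimed. Compound 2 gives 1170 nM, and the step of a 22-fold lower number from compound 1 to compound 2 (1.34 log units; beyond the scatter) is the one clear movement in the set. That step is the change (hydroxymethyl in place of carboxy on a saturated chain carbon, three bonds along the chain from an amine nitrogen in a ring).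

Compound 3 carries a different core from compound 1; the difference between the two cores is not broken down here. Compound 4 `OCCCN1CCC[C@H]1c1nc(-c2ccc3ccccc3c2)no1` is not yet measured. It is reached from compound 3 by the change (hydroxymethyl in place of carboxy on a saturated chain carbon, two bonds along the chain from an amine nitrogen in a ring). Among the compounds with values here, this is the same kind of change as the one from compound 1 to compound 2, not the same one: the place differs, the chain carbon being two bonds along the chain from the amine nitrogen rather than three.

Within the data shown here, since the step of a 22-fold lower number from compound 1 to compound 2 (1.34 log units; beyond the scatter) is large and beyond the scatter, the expectation for compound 4 is a step of roughly that size in the same direction, an 18-fold lower number from compound 3 to compound 4 (1.25 log units; beyond the scatter), with the caveat that only one such step is known and it sits on a different core and at a different place. The estimated value for compound 4 in this assay is 1600 nM, expected to fall between 400 nM and 7000 nM.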

Compound 4, half-maximal inhibitory concentration: 20500 nM
The estimate for compound 4 lay 13-fold (1.11 log units) below the measured number; measured number outside the range, above it.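

In this assay, hydroxymethyl in place of carboxy on a saturated chain carbon, two bonds along the chain from an amine nitrogen in a ring, gives a 1.4-fold lower number from compound 3 to compound 4 (0.14 log units; within the scatter), so compound 3 and compound 4 cannot be told apart in this read-out. The large step seen on the core of compound 1 therefore does not carry over in size to the core of compound 3, and the effect of this change cannot be read as a constant for the series: the same change on two cores in this assay, a 22-fold lower number (1.34 log units; beyond the scatter) from compound 1 to compound 2 and a 1.4-fold lower number (0.14 log units; within the scatter) from compound 3 to compound 4, 16-fold (1.20 log units) apart, beyond the scatter of two such steps

Within the data shown here, this does not show that the core alone sets the size of the step: the two pairs also differ in the place of the change, two bonds along the chain in one and three bonds in the other, and with only two pairs neither difference can be singled out.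

Still open, as far as these compounds go, is whether the core or the place decides the outcome; the same change on a longer chain on the core of compound 3, or on a shorter chain on the core of compound 1, would separate the two. Also open, from the compounds shown here alone, is how an amide or an amine at the end of the chain would read on either core.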